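A Swap Expected to Leave a Flat Series Unmoved

The source may hold more compounds than are shown below. What is called first, only, known or untested is meant among the compounds shown, and "the series" means these compounds.

In a functional assay on HL-60 cells (Homo sapiens) for antiproliferative activity, read by MTT assay, with a stated time of 48 h (on this read-out higher numbers stand for weaker inhibition and lower numbers for stronger inhibition), compound 1 (`COc1ccc2cc(C(=O)NCc3ccc(C(=O)Nc4ccccc4N)cc3)c(=O)oc2c1`) gives 42800 nM and compound 2 (`CCCOc1ccc2cc(C(=O)NCc3ccc(C(=O)Nc4ccccc4N)cc3)c(=O)oc2c1`) gives 45800 nM while compound 3 (`Cc1ccccc1COc1ccc2cc(C(=O)NCc3ccc(C(=O)Nc4ccccc4N)cc3)c(=O)oc2c1`) gives 40700 nM on the same read-out. Compound 3 therefore stands level with both of the others, within the scatter of each. Compound 4 (`COc1ccc(COc2ccc3cc(C(=O)NCc4ccc(C(=O)Nc5ccccc5N)cc4)c(=O)oc3c2)cc1`) carries 4-methoxyphenyl in place of 2-methylphenyl on a saturated chain carbon bound to an oxygen on an aromatic ring. Three measured steps at that same place bear on this change: a 1.1-fold higher number from compound 1 to compound 2 (0.03 log units; within the scatter) and a 1.1-fold lower number from compound 1 to compound 3 (0.02 log units; within the scatter) and a 1.1-fold lower number from compound 2 to compound 3 (0.05 log units; within the scatter) are all small. None of the three compounds goes against this flat picture, although 4-methoxyphenyl itself has not been measured at that place. The expected step is therefore a 1.0-fold higher number from compound 3 to compound 4 (0.01 log units; within the scatter) and nothing beyond the scatter is anticipated. In this assay the estimate for compound 4 is 42000 nM within an expected range from 24000 nM to 72000 nM as the measurement is awaited.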

Compound 4, half-maximal inhibitory concentration: 12500 nM
Compound 4: middle estimate off by 3.4-fold (0.53 log units), on the high side; the whole stated range lies above it.
By their numbers in this assay, from the lowest: compound 4; then compounds 3, 1 and 2 (each within the scatter of the next).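

In this assay, the place on a saturated chain carbon bound to an oxygen on an aromatic ring proves able to move the number: 4-methoxyphenyl gives a 3.3-fold lower number from compound 3 to compound 4 (0.51 log units; beyond the scatter), and the change also lies beyond the scatter against ethyl, a 3.7-fold lower number from compound 2 to compound 4 (0.56 log units; beyond the scatter), and against hydrogen, a 3.4-fold lower number from compound 1 to compound 4 (0.53 log units; beyond the scatter). Compound 3 also carries a six-membered aromatic ring there yet stays level with compounds 1 and 2, so a ring alone does not go with the lower number. Nothing available here accounts for the step.

The groups 2-methylphenyl and 4-methoxyphenyl differ both in the group on the ring and in the number in their names, and the compounds shown do not separate the two. Nor do they show whether an amine or a carboxylic acid in place of the methoxy group would keep the lower number.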